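From Compound 1 to Compound 3: An Expected Cytotoxicity Value

The source may report more compounds than this note shows. Statements on the series, on what has been measured and on what is new or still open speak of the compounds shown alone.

Compound 1 `O=[N+]([O-])c1ccc(NC(=S)NCCNS(=O)(=O)c2ccc(-c3ccccc3O[C@H]3CC[C@@H](O)CC3)s2)cc1`: 20000 nM
Compound 2 `O=[N+]([O-])c1ccc(NC(=S)N2CCN(S(=O)(=O)c3sccc3-c3ccccc3Oc3ccc(O)c(O)c3)CC2)cc1`: > 20000 nM

In an ADME assay on HEK-293T cells (Homo sapiens) for cytotoxicity, read by CCK-8 assay, with a stated time of 48 h (a lower number here means a stronger inhibitor, a higher number a weaker inhibitor), compound 1 gives 20000 nM. Compound 2 reaches only a limit of this assay, recorded as > 20000 nM, and not a number. This matches (the limit of > 20000 nM in this assay, at which 1 of the 2 values shown sits). Among the measured compounds shown here, compound 1 is thus the only compound in this assay with a measured value rather than a limit, and no pair of measured compounds differing in a single place exists, so no measured step is available as a guide.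

Compound 3 `O=[N+]([O-])c1ccc(NC(=S)NCCNS(=O)(=O)c2ccc(-c3ccccc3OCc3ccccc3)s2)cc1` differs from compound 1 by benzyl in place of 4-hydroxycyclohexyl on an oxygen on an aromatic ring. With compound 1 standing where it does, the step of no change at the digits printed from compound 1 to compound 3 (within the scatter) is expected to be small, with no direction claimed beyond the usual scatter. Compound 3 is therefore estimated at 20000 nM in this assay, with a range from 8000 nM to 45000 nM.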

Compound 3, half-maximal inhibitory concentration: 8900 nM
The estimate for compound 3 lay 2.2-fold (0.35 log units) above the measured number; low and high end bracket the measured number.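

In this assay putting benzyl in place of 4-hydroxycyclohexyl on an oxygen on an aromatic ring gives a 2.2-fold lower number from compound 1 to compound 3 (0.35 log units; beyond the scatter) as the first measured step available, so the group on this oxygen does bear on the number, though the step is modest. The two groups are equal in heavy atoms, which means the step does not go with a change in that count. Benzyl differs instead in having an aromatic ring, no hydrogen-bond donor or acceptor and no defined stereocentres, and this single pair cannot separate these differences.

From the compounds shown here alone, whether an amine, a carboxylic acid or a longer chain on this oxygen would move the number further remains open. Nothing shown gives a cause for the step.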